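Cyano for Hydroxymethyl on a Shared Fused Core

This account rests on a few compounds, and the source may have more. Where it says the series, first, only, none or still open, it means among the compounds named here.

Compound 2 `Cc1ccc2c(Cc3nn4c(CO)c(-c5ccc(Cl)cc5)nc4s3)coc2c1` is measured in a functional assay on the whole organism (strain Wistar albino) for inhibition, with Rattus norvegicus as the target, read by paw edema, with a stated time of 2 h, at a dose of 100 mg/kg by the oral route (a higher number here means more inhibition at the dose given (going by the name of the read-out), a lower number less inhibition), where compound 2 gives 28.9%. Compound 1 `Cc1ccc2c(Cc3nn4cc(-c5ccc(Cl)cc5)nc4s3)coc2c1` gives 42.1%, and compound 3 `Cc1ccc2c(Cc3nn4c(CO)c(-c5ccc(Br)cc5)nc4s3)coc2c1` gives 13.1%; compound 2 thus stands second highest of the three numbers, with a number 13.2 percentage points lower from compound 1 to compound 2 (beyond the scatter) and a number 15.8 percentage points lower from compound 2 to compound 3 (beyond the scatter). Compound 4 `Cc1ccc2c(Cc3nn4c(C#N)c(-c5ccc(Cl)cc5)nc4s3)coc2c1` differs from compound 2 in one place: cyano in place of hydroxymethyl on an aromatic carbon. Neither measured step exchanges hydroxymethyl for cyano. The step from compound 1 to compound 2 shows that adding hydroxymethyl on an aromatic carbon lowered inhibition, and the step from compound 2 to compound 3 concerns a different group, so the size of a number 1.1 percentage points higher from compound 2 to compound 4 (within the scatter) is expected to remain within the scatter. Compound 4 is therefore estimated at 30%, within 15% to 45%.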

Compound 4, a percentage reported as inhibition, in the whole organism at one dose (the size of the read-out at that dose, not a potency): 28%
The estimate for compound 4 lay 2 percentage points above the measured number, and the stated range covers the measured number.
By their numbers in this assay, from the lowest: compound 3; then compounds 4 and 2 (each within the scatter of the next); then compound 1.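

In this assay, the step with cyano in place of hydroxymethyl is a number 0.9 percentage points lower from compound 2 to compound 4 (within the scatter), so at this carbon the two groups cannot be told apart, although only hydroxymethyl carries a hydrogen-bond donor. Cyano in place of hydrogen gives a number 14.1 percentage points lower from compound 1 to compound 4 (beyond the scatter), showing that the drop seen with hydroxymethyl also occurs with a second group at this position. No measurement offered here explains this result. As far as these compounds go, whether an amine or a carboxylic acid at this carbon would also fall below compound 1 42.1% remains open. So does whether bromo in place of chloro would lower the number with cyano present.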